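The source may report more compounds than this note shows. Statements on the series, on what has been measured and on what is new or still open speak of the compounds shown alone.

Measured so far:
Compound 1, `CC(=O)/C(=C\c1c(-c2ccccc2)[nH]c2ccccc12)S(=O)(=O)c1ccccc1`: 832 nM
Compound 2, `COc1ccc2[nH]c(-c3ccccc3)c(/C=C(\C#N)S(=O)(=O)c3ccccc3)c2c1`: 3100 nM

In a functional assay on SK-MEL-5 cells (Homo sapiens) for inhibition, read by sulforhodamine B assay, with a stated time of 48 h (a lower number here means a stronger inhibitor of growth, a higher number a weaker inhibitor of growth), compound 1 gives 832 nM and compound 2 gives 3100 nM. Compound 2 therefore carries the higher of the two numbers, the weaker inhibition of growth, and its gap to compound 1 lies beyond the usual scatter. These two compounds differ in more than one place, however, so their gap cannot be laid at the door of any single change.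

Compound 3, `N#C/C(=C\c1c(-c2ccccc2)[nH]c2ccccc12)S(=O)(=O)c1ccccc1`, has not yet been measured in this assay. It differs from compound 2 in one place only: hydrogen in place of methoxy on an aromatic carbon. No measured pair isolates this particular change, so its effect is not known from the data shown. With nothing else to go on, a modest step is expected, leaning toward a lower number, though it may well stay within the scatter; the expected step is a 1.7-fold lower number from compound 2 to compound 3 (0.24 log units; within the scatter). Compound 3 is accordingly estimated to give 1800 nM in this assay, with a plausible range from 600 nM to 5500 nM.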

Compound 3, concentration for 50% growth inhibition: 1820 nM
The estimate for compound 3 lay 1.0-fold (0.00 log units) below the measured number, and the stated range covers the measured number.
By their numbers in this assay, from the lowest: compound 1; then compounds 3 and 2 (each within the scatter of the next).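

In this assay hydrogen in place of methoxy on an aromatic carbon gives only a small shift (a 1.7-fold lower number from compound 2 to compound 3 (0.23 log units; within the scatter)), so these two groups cannot be told apart at this position, at least on a core that carries cyano on the chain. The other change, cyano in place of acetyl on a double-bonded chain carbon, is the first single-place change here to exceed the scatter, though only modestly (a 2.2-fold higher number from compound 1 to compound 3 (0.34 log units; beyond the scatter)): the compound with acetyl, compound 1, has the lower number and so is the stronger inhibitor of growth, which makes this chain carbon the one position shown where the choice of group registers in the read-out. Nothing presented explains why either group behaves as it does.

From the compounds shown here alone, whether methoxy would also make so little difference on a core that carries acetyl remains open, since the effect at one position may depend on the group at the other. Going by these compounds, it is also open how an amine or a chlorine atom on that aromatic carbon, or a carboxylic acid or a longer ketone chain on the chain carbon, would compare.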